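The source may report more compounds than this note shows. Statements on the series, on what has been measured and on what is new or still open speak of the compounds shown alone.

Compound 2, with the structure `CSc1nc(NCc2ccccc2)c2ccccc2n1`, is one of two measured compounds; in a functional assay on CCRF-CEM cells (Homo sapiens) for cytotoxicity, read by MTT assay, with a stated time of 72 h (on this read-out lower numbers stand for stronger inhibition of growth and higher numbers for weaker inhibition of growth), compound 2 gives 87900 nM. The other is compound 1, with the structure `CSc1ccc(CNc2nc([SeH])nc3ccccc23)cc1`; in this assay compound 1 gives 71900 nM. The two numbers lie within the usual scatter of each other, so nothing separates them. Within the data shown here, no pair of measured compounds differs in only one place, so no single structural step has yet been observed.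

Compound 3, with the structure `CSc1ccc(CNc2nc(SC)nc3ccccc23)cc1`, is not yet measured. It differs from compound 2 as follows: methylsulfanyl in place of hydrogen on an aromatic carbon

Both measured compounds sit at weak inhibition of growth, and there is nothing here that points to a large shift from such a change; only a small step, or none beyond the scatter, is expected, a 1.3-fold lower number from compound 2 to compound 3 (0.10 log units; within the scatter). For compound 3 the value in this assay is estimated at 70000 nM, with a range from 25000 nM to 200000 nM.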

Compound 3, concentration for 50% growth inhibition: > 100000 nM
Compound 3: no number, only a limit (the forecaster's own chance of this, stated with the estimate: 15%); at least 1.4-fold (0.15 log units) between middle value and limit.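

Compound 3 gives no number in this assay, only a limit of the assay: the limit of > 100000 nM in this assay, at which 1 of the 3 values shown sits. Among these compounds, this also supplies the first steps that differ in one place: methylsulfanyl in place of hydrogen, on an aromatic carbon para to a large group, gives an at least 1.1-fold higher number from compound 2 to compound 3 (0.05 log units; that floor lies within the scatter), and a group of 2 heavy atoms in place of one selenium atom gives an at least 1.3-fold higher number from compound 1 to compound 3 (0.14 log units; that floor lies within the scatter). Both floors lie within the scatter, so neither step establishes a real change, but with methylsulfanyl at this place, compound 3 shows no growth inhibition that this read-out can put a number on.

As far as these compounds go, how far the true value of compound 3 lies past its limit stays open. So does the effect of an amine or a carboxylic acid on that same aromatic carbon.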